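Ring-nitrogen substituent series: cyclohexyl for methyl

The compounds below may be only part of what the source reports. "The series", "measured", "known", "first", "only" and "open" are said of these compounds alone.

Three analogues share one core. Compound 1 `CCCCOc1ccc(-c2c(C)[nH]c(=O)n2C)cc1` gives 5100 nM in a functional assay on brain (Rattus norvegicus, strain Wistar) for inhibition (on this read-out lower numbers stand for stronger inhibition and higher numbers for weaker inhibition), compound 2 `CCCCCOc1ccc(-c2c(C)[nH]c(=O)n2C)cc1` gives 4500 nM, and compound 3 `Cc1[nH]c(=O)n(C)c1-c1ccc(C2CCCCC2)cc1` gives 10000 nM. Compound 3 has the highest number of the three: a 2.0-fold higher number from compound 1 to compound 3 (0.29 log units; within the scatter) and a 2.2-fold higher number from compound 2 to compound 3 (0.35 log units; beyond the scatter), while a 1.1-fold lower number from compound 1 to compound 2 (0.05 log units; within the scatter).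

Compound 4 `Cc1[nH]c(=O)n(C2CCCCC2)c1-c1ccc(C2CCCCC2)cc1` differs from compound 3 by cyclohexyl in place of methyl on an aromatic nitrogen. Among the compounds with values here, none of the measured steps touches the aromatic nitrogen; all three vary the group on the aromatic carbon, and none exceeds modest size. Within the data shown here, no step bears directly on this change, so no direction beyond the scatter is expected. For compound 4 the number is estimated at 10000 nM (range 3000 nM to 35000 nM), an expected step of no change at the digits printed from compound 3 to compound 4 (within the scatter).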

Compound 4, half-maximal inhibitory concentration: 28900 nM
Compound 4: middle estimate off by 2.9-fold (0.46 log units), on the low side, and the stated range covers the measured number.
By their numbers in this assay, from the lowest: compounds 2, 1 and 3 (each within the scatter of the next, the first and the last beyond it); then compound 4.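

Cyclohexyl in place of methyl on the aromatic nitrogen gives a 2.9-fold higher number from compound 3 to compound 4 (0.46 log units; beyond the scatter) in this assay, so this position responds to change, with a modest weakening of inhibition that lies beyond the scatter. Within the data shown here, this is the only step at this position, and the reading rests on this single pair. Nothing available explains the shift.

From the compounds shown here alone, whether an ethyl or a benzyl on this nitrogen would give a similar loss remains open. Also open, going by these compounds, is whether the step holds with butoxy or pentyloxy on the aromatic ring in place of cyclohexyl.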